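Fluoro in Place of Sulfamoyl: Expected Change in Cytotoxicity

A few compounds are considered here, and "the series" means these few. Any claim that something is new, unique, unknown or untested is made for them only; others in the source may bear on it.

Measured so far:
compound 1 `CC(C)n1ncc2c(C(=O)Nc3ccc(F)c(S(N)(=O)=O)c3)cc(-c3cccs3)nc21`: 50000 nM
compound 2 `CC(C)n1ccc2c(C(=O)Nc3ccc(F)cc3)cc(-c3cccs3)nc21`: > 200000 nM, a limit of the assay
compound 3 `CC(C)n1ncc2c(C(=O)N3CCc4cc(F)ccc43)cc(-c3cccs3)nc21`: > 200000 nM, a limit of the assay

All three compounds were tested in an ADME assay on LLC-MK2 cells (Macaca mulatta) for cytotoxicity, read by spectrophotometry and crystal violet staining, with a stated time of 4 days; on this read-out lower numbers stand for higher toxicity in this test and higher numbers for lower toxicity in this test. Compound 2 sits at the limit of > 200000 nM in this assay, at which 2 of the 3 values shown sit. Compound 3 sits at the same limit. Compound 1 gives 50000 nM in this assay. For the measured compounds named here, it is therefore the only compound of the three with a number rather than a limit, and that number stands below the limit at which the other two were reported.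

The unmeasured compound 4 `CC(C)n1ncc2c(C(=O)Nc3ccc(F)c(F)c3)cc(-c3cccs3)nc21` differs from compound 1 by fluoro in place of sulfamoyl on an aromatic carbon. Going by the values given here, no pair of measured compounds that differ in exactly one place is available, so no measured step guides this change directly. The two compounds that lack a sulfamoyl group, compound 2 and compound 3, both gave only a limit in this assay, so a step upward, toward lower toxicity, is expected for compound 4; the step from compound 1 is estimated as a 2.4-fold higher number from compound 1 to compound 4 (0.38 log units; beyond the scatter). Compound 4 is accordingly expected to give about 120000 nM in this assay, within a range from 40000 nM to 350000 nM, with a real chance that only a limit is reported.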

Compound 4, half-maximal cytotoxic concentration: > 200000 nM
Compound 4 gave a limit, no number; the forecaster's own chance of this, stated with the estimate: 45%; middle value at least 1.6-fold (0.22 log units) away from the limit.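

This is the first pair among the compounds shown that differ in one place only, so the effect of this change can now be read directly: the measurements in this assay show an at least 4.0-fold higher number from compound 1 to compound 4 (0.60 log units; beyond the scatter) for fluoro in place of sulfamoyl on an aromatic carbon. Going by these compounds, compound 4 gives > 200000 nM in this test, which is a limit of the assay and not a number, so the step is a minimum and its full size stays unknown. Within this pair, the sulfamoyl group at this position goes with the higher toxicity in this test, and most of the results now stand at one limit: the limit of > 200000 nM in this assay, at which 3 of the 4 values shown sit.

The compounds shown leave open whether the lower number of compound 1 is special to sulfamoyl or would also appear with another group on this aromatic carbon, such as an amine or a carboxylic acid. They also cannot say why sulfamoyl at this position goes with higher toxicity, or whether the same holds on a different core.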